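The compounds below may be only part of what the source reports. "The series", "measured", "known", "first", "only" and "open" are said of these compounds alone.

Compound 1 (`CCn1c(/C=C2\SC(=O)N(CC(=O)N3CCCCC3)C2=O)nc2ccccc21`) was tested in a functional assay on A549 cells (Homo sapiens) for inhibition, read by MTT assay, with a stated time of 48 h; a higher number here means a weaker inhibitor, a lower number a stronger inhibitor. Compound 1 reads > 50000 nM, which is a limit of the assay and not a measured number. Compound 3 (`Cn1c(/C=C2\SC(=O)N(CC(=O)N3CCCC3)C2=O)nc2ccccc21`) reads > 50000 nM, again a limit. The series is therefore dominated by the limit of > 50000 nM in this assay, at which 2 of the 3 values shown sit. Going by the values given here, the only actual number comes from compound 2 (`CCn1c(/C=C2\SC(=O)N(CC(=O)N3CCc4cc(OC)c(OC)cc4C3)C2=O)nc2ccccc21`), which gives 26200 nM.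

Compound 4 (`CCn1c(/C=C2\SC(=O)N(CC(=O)N3CCOCC3)C2=O)nc2ccccc21`) keeps the core of compound 1 and carries morpholin-4-yl in place of piperidin-1-yl on a carbonyl carbon. Among the compounds with values here, no measured pair of compounds isolates this change, so the expectation rests on compound 1, with its limit of > 50000 nM. The expected step, a number no higher from compound 1 to compound 4 (the limit leaves the size open), is estimated to lie within the scatter, with no direction expected in this assay. Compound 4 is expected to read about 50000 nM, with an estimated range from 25000 nM to 100000 nM, and may well be reported only as a limit.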

Compound 4, half-maximal inhibitory concentration: > 50000 nM
Compound 4: no number, only a limit; the forecaster's own chance of this, stated with the estimate: 80%; the middle value sits exactly at the limit.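

In this assay compound 4 reads > 50000 nM, a limit and not a number. Going by these compounds alone, compound 1 also stands at a limit, so no step between compound 1 and compound 4 can be read. The compounds shown leave open whether morpholin-4-yl and piperidin-1-yl differ at all in this assay.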